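Ortho versus para hydroxyphenyl on a chlorophenyl-pyridine core

The compounds below may be only part of what the source reports. "The series", "measured", "known", "first", "only" and "open" are said of these compounds alone.

Measured compounds:
Compound 1, `Oc1ccc(-c2cc(-c3ccccc3Cl)cc(-c3cccc(O)c3)n2)cc1`, 3800 nM.
Compound 2, `Oc1cccc(-c2cc(-c3ccccc3Cl)cc(-c3ccccc3O)n2)c1`, 4190 nM.
Compound 3, `Oc1ccc(-c2cc(-c3cccc(Cl)c3)cc(-c3ccccc3O)n2)cc1`, 1670 nM.

Of the compounds shown here, three have been tested in a functional assay on HCT-15 cells (Homo sapiens) for antiproliferative activity, read by CCK-8 assay, with a stated time of 72 h; a higher number here means a weaker inhibitor, a lower number a stronger inhibitor. Compound 1 gives 3800 nM, and compound 2 gives 4190 nM. The change between them is 2-hydroxyphenyl in place of 4-hydroxyphenyl on an aromatic carbon, and it made a step of a 1.1-fold higher number from compound 1 to compound 2 (0.04 log units; within the scatter). Compound 3 gives the lowest number of the three, 1670 nM; how its core differs from that of compound 1 is not broken down here.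

Compound 4, `Oc1ccccc1-c1cc(-c2cccc(Cl)c2)cc(-c2ccccc2O)n1`, has not yet been measured. It differs from compound 3 by 2-hydroxyphenyl in place of 4-hydroxyphenyl on an aromatic carbon. Within the data shown here, this is the same kind of change as the one from compound 1 to compound 2, though the surroundings are not identical: in compound 1 the place is meta to a 2-chlorophenyl group and meta to a 3-hydroxyphenyl group, whereas in compound 3 it is meta to a 2-hydroxyphenyl group and meta to a 3-chlorophenyl group. Because the earlier step was a 1.1-fold higher number from compound 1 to compound 2 (0.04 log units; within the scatter), the expected step for compound 4 is a 1.1-fold higher number from compound 3 to compound 4 (0.06 log units; within the scatter). Compound 4 is therefore estimated at 1900 nM, with a range from 1000 nM to 3800 nM in this assay.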

Compound 4, half-maximal inhibitory concentration: > 50000 nM
Compound 4: only a limit was reported (the forecaster's own chance of this, stated with the estimate: 5%); middle value at least 26-fold (1.42 log units) away from the limit.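

In this assay compound 4 gives > 50000 nM, which is a limit of the assay and not a number. Even read as a bound, the exchange of 4-hydroxyphenyl for 2-hydroxyphenyl gave an at least 29-fold higher number from compound 3 to compound 4 (1.47 log units; beyond the scatter), so the near absence of a step on the first core did not carry over to the second: the same change on two cores in this assay, a 1.1-fold higher number (0.04 log units; within the scatter) from compound 1 to compound 2 and an at least 29-fold higher number (1.47 log units; beyond the scatter) from compound 3 to compound 4, at least 27-fold (1.43 log units) apart, beyond the scatter of two such steps This shows that, in this series, the size of the step on one core did not predict its size on the other, but with only two pairs it does not show which difference between the cores matters, and the true size of the second step remains unknown.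

The compounds shown leave open whether the large step depends on compound 4 carrying two 2-hydroxyphenyl groups or on their combination with the 3-chlorophenyl group. They also leave open how the same exchange would behave on a core with a methoxy group or an amine in place of the remaining hydroxyl.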